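The compounds below may be only part of what the source reports. "The series", "measured", "known", "first", "only" and "open" are said of these compounds alone.

Measured in a functional assay on HeLa cells (Homo sapiens) for antiproliferative activity, with a stated time of 24 h; on this read-out higher numbers stand for weaker inhibition and lower numbers for stronger inhibition:
Compound 1 `NC(=O)c1c(NC(=O)c2ccccc2Cl)sc2c1CCN(Cc1ccc(Cl)cc1)C2` gives > 50000 nM, a limit of the assay.
Compound 2 `NC(=O)c1c(NC(=O)c2ccccc2Cl)sc2c1CCN(Cc1ccc([N+](=O)[O-])cc1)C2` gives 46100 nM.
Compound 3 `NC(=O)c1c(NC(=O)c2ccccc2Cl)sc2c1CCN(Cc1ccc(Cl)cc1Cl)C2` gives 21100 nM.

Compound 3 holds the lower of the two values that are numbers. Compound 1 sits at the limit of > 50000 nM in this assay, at which 1 of the 3 values shown sits. The steps of an at least 2.3-fold lower number from compound 1 to compound 3 (0.37 log units; beyond the scatter) and a 2.2-fold lower number from compound 2 to compound 3 (0.34 log units; beyond the scatter) show that exchanging the group on the ring nitrogen shifts this assay only modestly, while an at least 1.0-fold lower number from compound 1 to compound 2 (0.03 log units; that floor lies within the scatter) stays within the scatter. Compound 4 `NC(=O)c1c(NC(=O)c2ccccc2Cl)sc2c1CCN(C(=S)Nc1ccccc1F)C2` carries a group of 10 heavy atoms (7 carbon, 1 nitrogen, 1 fluorine, 1 sulfur; one six-membered aromatic ring of carbon only) in place of a group of 9 heavy atoms (7 carbon, 2 chlorine; one six-membered aromatic ring of carbon only), on an amine nitrogen in a ring. Among the compounds with values here, no measured step covers an exchange of this kind on that nitrogen, and the measured values all lie in a narrow, weak band. Compound 4 is therefore expected near 30000 nM, with a range of 9000 nM to 50000 nM. The expected step is a 1.4-fold higher number from compound 3 to compound 4 (0.15 log units; within the scatter), not clearly beyond the scatter.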

Compound 4, half-maximal inhibitory concentration: 28700 nM
The estimate for compound 4 lay 1.0-fold (0.02 log units) above the measured number, within the range that was stated.
By their numbers in this assay, from the lowest: compounds 3, 4 and 2 (each within the scatter of the next, the first and the last beyond it). At a limit, above all of these: compound 1.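

On the amine nitrogen in a ring, an entering group with a hydrogen-bond donor, a hydrogen-bond acceptor and a double bond outside aromatic rings replaces the benzyl groups, yet the numbers in this assay stay in the same weak band: the steps of a 1.4-fold higher number from compound 3 to compound 4 (0.13 log units; within the scatter) and a 1.6-fold lower number from compound 2 to compound 4 (0.21 log units; within the scatter) are both within the scatter. The step of an at least 1.7-fold lower number from compound 1 to compound 4 (0.24 log units; that floor lies within the scatter) has a floor within the scatter and gives no order. Compound 1 remains a limit and not a number: the limit of > 50000 nM in this assay, at which 1 of the 4 values shown sits.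

From the compounds shown here alone, whether an amine, a carboxylic acid or a longer chain on this nitrogen would leave that band stays open. Also open, going by these compounds, is what the sulfur of the entering group contributes, compared with an oxygen in its place.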